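The source may hold more compounds than are shown below. What is called first, only, known or untested is meant among the compounds shown, and "the series" means these compounds.

Of the compounds shown here, three built on one shared core have been tested in a functional assay on the whole organism (strain Swiss) with Mus musculus as the target, in the maximal electroshock model, with a stated time of 0.25 h, at a dose of 300 mg/kg by the intraperitoneal route; on this read-out lower numbers stand for a weaker effect and higher numbers for a stronger effect at the one dose given. Compound 3 `CC(C(=O)N1CCN(c2ccccc2)CC1)N1C(=O)CCC1=O` gives 100%, the highest of the three numbers, and its unsubstituted phenyl ring is the simplest of the set. Compound 1 `COc1cccc(N2CCN(C(=O)C(C)N3C(=O)CCC3=O)CC2)c1` carries a methoxy group on that ring and gives 75%; replacing the methoxy with hydrogen gave a number 25 percentage points higher from compound 1 to compound 3 (beyond the scatter). Compound 2 `COCC(C(=O)N1CCN(c2cccc(C(F)(F)F)c2)CC1)N1C(=O)CCC1=O` differs from compound 3 in two places at once, a trifluoromethyl group on the ring and a methoxymethyl group in place of a methyl; in this assay compound 2 gives 25%, and no single step can be read from it.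

Compound 4 `CC(C(=O)N1CCN(c2ccc(F)cc2)CC1)N1C(=O)CCC1=O` is the next step: fluoro in place of hydrogen on an aromatic carbon. Among the compounds with values here, no measured step involves a fluoro group, so the only guide is indirect. Within the data shown here, the one step available, from methoxy to hydrogen, shows that a ring substituent coming off went with a higher number, and both substituted compounds sit below compound 3. Among the measured compounds shown here, since compound 3 already stands at the top of this read-out, no upward step is possible, and a small downward step or none beyond the scatter is expected, a number 12 percentage points lower from compound 3 to compound 4 (beyond the scatter). Compound 4 is therefore estimated at 88%, with a range from 55% to 100%.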

Compound 4, a percentage reported as activity, at one dose (the size of the read-out at that dose, not a potency): 100%
Estimate against measurement, compound 4: 12 percentage points below, within the range that was stated.
By their numbers in this assay, from the lowest: compound 2; then compound 1; then compounds 3 and 4 (each within the scatter of the next).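

In this assay, within the data shown here, fluoro on an aromatic carbon para to a large group is the first ring substituent in this set that leaves the read-out where it was, with no change at the digits printed from compound 3 to compound 4 (within the scatter) for this replacement of hydrogen. A substituent on this ring therefore does not always go with a lower number, and the lower number of compound 1 cannot be read as a rule for all ring substituents. The swap of 3-methoxyphenyl for 4-fluorophenyl gives a number 25 percentage points higher from compound 1 to compound 4 (beyond the scatter) and matches the earlier loss with methoxy, but it changes both the group and its place on the ring, so it cannot tell which of the two matters; nothing available explains the result.

Compound 3 and compound 4 both stand at the top of this read-out at a single dose, so any real difference in strength between them stays hidden. As far as these compounds go, whether a chloro group, a bromo group or an amine at the same place on the ring would also keep the number this high remains open.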